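Compound 2 to Compound 4: An Expected Step

This account rests on a few compounds, and the source may have more. Where it says the series, first, only, none or still open, it means among the compounds named here.

Compound 1, `O=S(=O)(c1ccc(Cl)cc1)N1CC(c2nc(-c3cccc(Cl)c3)no2)C1`, 170 nM
Compound 2, `COC1CCN(C(=O)N2CC(c3nc(-c4cccc(Cl)c4)no3)C2)CC1`, > 10000 nM
Compound 3, `O=C(c1ccc(Cl)cc1)N1CC(c2nc(-c3cccc(F)c3)no2)C1`, > 10000 nM

Of the compounds shown here, three built on a shared core have been tested in an assay on HEK293 cells for negative allosteric modulation of metabotropic glutamate receptor 5 (Homo sapiens), read by FLIPR; on this read-out lower numbers stand for stronger inhibition and higher numbers for weaker inhibition. Compound 1 gives a number, 170 nM. For compound 2 the outcome is only a limit of the assay, > 10000 nM, not a measured number. For compound 3 the outcome is likewise only a limit, > 10000 nM. Compound 2 therefore stands at the limit of > 10000 nM in this assay, at which 2 of the 3 values shown sit, and among the three compounds only compound 1 yields a number at all.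

The compound not yet measured is compound 4, `O=C(c1ccc(F)cc1)N1CC(c2nc(-c3cccc(Cl)c3)no2)C1`. It differs from compound 2 in a single place: 4-fluorophenyl in place of 4-methoxypiperidin-1-yl on a carbonyl carbon. Compound 3 also carries an aromatic ring on its carbonyl carbon and gave only a limit, while compound 1 with its number differs from all of these in the group on the ring nitrogen.

For the measured compounds named here, no step between measured compounds is available to set a scale. The step from compound 2 to compound 4 is expected to be an at least 1.1-fold lower number from compound 2 to compound 4 (0.04 log units; that floor lies within the scatter), that is, no movement beyond the usual scatter away from the limit. Compound 4 is estimated at 9000 nM, with a range from 2500 nM to 30000 nM, and a limit rather than a number is the more likely report.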

Compound 4, half-maximal inhibitory concentration: 4000 nM
Beside the measured number, compound 4's estimate is 2.3-fold (0.35 log units) above it, within the range that was stated.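

Replacing 4-methoxypiperidin-1-yl with 4-fluorophenyl on the carbonyl carbon gives an at least 2.5-fold lower number from compound 2 to compound 4 (0.39 log units; beyond the scatter) in this assay. This is the first pair shown that differs in one place only, and it shows that the group on this carbonyl carbon can move the number beyond the usual scatter, here with an aromatic ring of carbon only entering and a non-aromatic ring containing nitrogen leaving. The step is only a floor, and the full gap could be larger, since compound 2 gives a limit rather than a number: the limit of > 10000 nM in this assay, at which 2 of the 4 values shown sit.

For the compounds shown here, with only two groups compared at this place, it remains open whether the change follows the aromatic ring itself or the fluorine it carries, a question that plain phenyl or an open-chain amine such as dimethylamino on the same carbonyl carbon would help to separate. Compound 1 and compound 3 each differ from compound 4 in more than one place, and neither pair can show what the sulfonyl link or the swap of chlorine and fluorine does alone.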